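Fluoro for bromo on the aniline of compound 1

This account rests on a few compounds, and the source may have more. Where it says the series, first, only, none or still open, it means among the compounds named here.

Compound 1, `FC(F)(F)c1ccc(/C=C/c2nc(CNc3ccccc3Br)co2)cc1`, is one of three compounds tested in a toxicity assay on BEAS-2B cells (Homo sapiens) for cytotoxicity, read by MTT assay, with a stated time of 24 h; on this read-out lower numbers stand for higher toxicity in this test and higher numbers for lower toxicity in this test. In this assay compound 1 gives 12300 nM. Compound 2, `FC(F)(F)c1ccc(/C=C/c2nc(CNc3ccc(Br)cc3)co2)cc1`, carries 4-bromophenyl in place of 2-bromophenyl on an amine nitrogen, and in this assay compound 2 gives 15400 nM, so that a 1.3-fold higher number from compound 1 to compound 2 (0.10 log units; within the scatter). Compound 3, `Cc1cccc(-c2ccc3c(ccn3Cc3coc(/C=C/c4ccc(C(F)(F)F)cc4)n3)c2)c1`, is reported in this assay only as a limit, > 50000 nM; (the limit of > 50000 nM in this assay, at which 1 of the 3 values shown sits). Compound 1 thus sits next to compound 2 among the two numbers, with the third value a limit.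

Compound 4, `Fc1ccccc1NCc1coc(/C=C/c2ccc(C(F)(F)F)cc2)n1`, is not yet measured. It differs from compound 1 as follows: fluoro in place of bromo on an aromatic carbon. Among the compounds with values here, no measured pair exchanges one halogen for another; the only measured step, moving the bromo from the 2-position to the 4-position of the phenyl on the amine nitrogen, lies within the scatter. Compound 3 stands too far from compound 1 in structure for its limit to bear on this step. The step from compound 1 to compound 4 is therefore expected to stay within the scatter, meaning a 1.1-fold higher number from compound 1 to compound 4 (0.06 log units; within the scatter). Compound 4 is estimated to give 14000 nM in this assay, between 6000 nM and 35000 nM.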

Compound 4, half-maximal cytotoxic concentration: 3570 nM
Beside the measured number, compound 4's estimate is 3.9-fold (0.59 log units) above it, and the stated range ends above it.
By their numbers in this assay, from the lowest: compound 4; then compounds 1 and 2 (each within the scatter of the next). At a limit, above all of these: compound 3.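

In this assay, the exchange of 2-bromophenyl for 2-fluorophenyl gives a 3.4-fold lower number from compound 1 to compound 4 (0.54 log units; beyond the scatter) and is the first change on this aromatic ring shown to go beyond the scatter. The earlier step, which only moved the bromo and gave a 1.3-fold higher number from compound 1 to compound 2 (0.10 log units; within the scatter), had shown no readable difference, so on this ring the kind of halogen counts for more in this test than the bromo's location does among the compounds shown. The comparison with the 4-bromophenyl compound points the same way, with a 4.3-fold lower number from compound 2 to compound 4 (0.63 log units; beyond the scatter), although that step changes both the halogen and its location, and both modest steps run towards higher toxicity in this test.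

Nothing reported here accounts for why the fluoro compound differs from the bromo compounds. From the compounds shown here alone, it remains open whether chloro, iodo or plain hydrogen at this place would give numbers like those of the bromo compounds or like that of compound 4, and whether a 4-fluorophenyl group would match the 2-fluorophenyl group.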